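Trifluoromethyl in Place of Nitro on the Aryl Urea

This account rests on a few compounds, and the source may have more. Where it says the series, first, only, none or still open, it means among the compounds named here.

Of the compounds shown here, three sharing one core have been measured in a functional assay on RPMI-8226 cells (Homo sapiens) for inhibition; a higher number here means a weaker inhibitor, a lower number a stronger inhibitor. Compound 1 `N#CC1CN1C(=O)Nc1ccc(Cl)c(Cl)c1` gives 2700 nM, compound 2 `N#CC1CN1C(=O)Nc1ccc(F)cc1` gives 5900 nM, and compound 3 `N#CC1CN1C(=O)Nc1ccc([N+](=O)[O-])cc1` gives 8600 nM. Compound 3 thus carries the highest of the three numbers, with compound 2 close by and compound 1 further off.

Compound 4 `N#CC1CN1C(=O)Nc1ccc(C(F)(F)F)cc1` differs from compound 3 by trifluoromethyl in place of nitro on an aromatic carbon. Among the compounds with values here, no measured pair changes nitro for trifluoromethyl, so the closest guide is the step of a 1.5-fold higher number from compound 2 to compound 3 (0.16 log units; within the scatter), which shows that swapping one small group for another on this aromatic carbon moved the number very little. The gap from compound 3 to compound 1 is the only one beyond the scatter, and it involves two chloro groups rather than a single change of this kind.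

For compound 4 in this assay the step of a 1.6-fold lower number from compound 3 to compound 4 (0.19 log units; within the scatter) is expected, a modest downward move that could easily fall inside the scatter. Compound 4 is therefore estimated at 5500 nM, within a range of 1800 nM to 16000 nM.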

Compound 4, half-maximal inhibitory concentration: 7800 nM
Compound 4: middle estimate off by 1.4-fold (0.15 log units), on the low side, within the range that was stated.
By their numbers in this assay, from the lowest: compound 1; then compounds 2, 4 and 3 (each within the scatter of the next).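

In this assay trifluoromethyl can now be set against two other groups on this aromatic carbon: against nitro the result is a 1.1-fold lower number from compound 3 to compound 4 (0.04 log units; within the scatter) and against fluoro it is a 1.3-fold higher number from compound 2 to compound 4 (0.12 log units; within the scatter) and both steps lie within the scatter. Together with the earlier step between fluoro and nitro, this means that the three groups cannot be told apart at this position, even though trifluoromethyl counts 0 hydrogen-bond acceptors where nitro counts 2. No supporting measurement is available to explain this sameness.

Still open, from the compounds shown here alone, is whether a quite different group at this position, such as an amine, a carboxylic acid or a longer chain, would shift the number beyond the scatter. Going by these compounds, compound 1 differs from these compounds in more than one place, so the effect of a single chloro group also remains unknown.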